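A few compounds are considered here, and "the series" means these few. Any claim that something is new, unique, unknown or untested is made for them only; others in the source may bear on it.

Measured compounds:
compound 1 `Cn1cc(-c2cnc3ccnc(N)c3c2)cn1`
compound 2 `Cn1cc(-c2cnc3ccc(NCc4ccc(F)cc4)nc3c2)cn1`
compound 3 `COc1ccc(CNc2ccc3ncc(-c4cnn(C)c4)cc3n2)cc1`

In a functional assay on A549 cells (Homo sapiens) for antiproliferative activity, read by MTT assay, with a stated time of 48 h (on this read-out lower numbers stand for stronger inhibition and higher numbers for weaker inhibition), compound 1 gives 33400 nM. Compound 2 reaches only the assay limit, > 50000 nM. Compound 3 likewise reaches only the limit, > 50000 nM. Among the compounds with values here, compound 1 thus holds the only number in the set; the other two values sit at the limit of > 50000 nM in this assay, at which 2 of the 3 values shown sit. Within the data shown here, the single step between measured compounds, a step that the two limits leave unreadable from compound 2 to compound 3, is left unreadable by the two limits.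

Compound 4 `Cn1cc(-c2cnc3ccnc(NC(=O)c4cccnc4)c3c2)cn1` differs from compound 1 by (pyridin-3-yl)carbonyl in place of hydrogen on a nitrogen on an aromatic ring. Among the measured compounds shown here, no measured step touches this nitrogen, and no step in the set is readable at all, so nothing measured bears on the change. Compound 4 is therefore expected near compound 1, estimated at 25000 nM with a range from 6000 nM to 50000 nM. The expected step of a 1.3-fold lower number from compound 1 to compound 4 (0.13 log units; within the scatter) is none beyond the scatter.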

Compound 4, half-maximal inhibitory concentration: > 50000 nM
Compound 4 gave a limit, no number; the forecaster's own chance of this, stated with the estimate: 35%; middle value at least 2.0-fold (0.30 log units) away from the limit.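

In this assay, within the data shown here, (pyridin-3-yl)carbonyl in place of hydrogen on this nitrogen gives an at least 1.4-fold higher number from compound 1 to compound 4 (0.17 log units; that floor lies within the scatter), the first measured change at this position. No lower number appears, but the printed floor of the step does not establish a loss beyond the scatter. Compound 4 gives a limit, not a number, and most of the series now sits there: the limit of > 50000 nM in this assay, at which 3 of the 4 values shown sit.

On these data alone, the true size of this step remains open. So does whether acetyl or a plain methyl on this nitrogen would give a readable number.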